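Replacing Acetyl with a Larger Group on Nitrogen

The source may hold more compounds than are shown below. What is called first, only, known or untested is meant among the compounds shown, and "the series" means these compounds.

In an ADME assay on BE(2)-C cells (Homo sapiens) for cytotoxicity, read by MTT assay, with a stated time of 20 h (on this read-out higher numbers stand for lower toxicity in this test and lower numbers for higher toxicity in this test), compound 2 `CC(=O)n1c(C(=O)N2CCC(C(=O)N(C)Cc3ccccc3)CC2)cc2ccccc21` gives > 50000 nM, which is a limit of the assay and not a number. Compound 1 `Cn1cnc(CNC(=O)C2CCN(C(=O)c3cc4ccccc4n3Cc3ccc(Cl)cc3)CC2)c1` gives > 50000 nM, also a limit. Together they make up (the limit of > 50000 nM in this assay, at which 2 of the 2 values shown sit), so no measured step is available as a guide. Compound 3 `CN(Cc1ccccc1)C(=O)C1CCN(C(=O)c2cc3ccccc3n2Cc2ccc(C(F)(F)F)cc2)CC1` carries 4-(trifluoromethyl)benzyl in place of acetyl on an aromatic nitrogen. Little or no change beyond the usual scatter is expected, and the estimated step is a number no higher from compound 2 to compound 3 (the limit leaves the size open). For compound 3 the estimate is 50000 nM, with an expected range of 20000 nM to 100000 nM.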

Compound 3, half-maximal cytotoxic concentration: 90300 nM
The estimate for compound 3 lay 1.8-fold (0.26 log units) below the measured number, and the stated range covers the measured number.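

No step from compound 2 to compound 3 can be read, because the value of compound 2 is a limit of the assay and not a number: the limit of > 50000 nM in this assay, at which 2 of the 3 values shown sit.

The compounds shown leave open how far 4-(trifluoromethyl)benzyl in place of acetyl moves this read-out.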